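A chlorophenyl swap on the amide nitrogen

This account rests on a few compounds, and the source may have more. Where it says the series, first, only, none or still open, it means among the compounds named here.

Measured in a functional assay on Bel-7402 cells (Homo sapiens) for inhibition, read by MTT assay, with a stated time of 24 h, tested at 0.1 ug/mL; a lower number here means less inhibition of growth, a higher number more inhibition of growth at the concentration tested:
Compound 1 `O=C(CCCCC(CCSC(=O)c1ccccc1)SC(=O)c1ccccc1)Nc1ccccc1Cl`: 5.72%
Compound 2 `O=C(CCCCC(CCSC(=O)c1ccccc1)SC(=O)c1ccccc1)Nc1cccc(Cl)c1`: 1.7%

Compound 2 stands within the scatter of compound 1, so the two cannot be ranked. Compound 3 `O=C(CCCCC(CCSC(=O)c1ccccc1)SC(=O)c1ccccc1)Nc1ccc(Cl)cc1` differs from compound 2 in one place: 4-chlorophenyl in place of 3-chlorophenyl on an amide-type nitrogen. Going by the values given here, one measured step bears on this change, 3-chlorophenyl in place of 2-chlorophenyl on the same amide-type nitrogen, and it gave a number 4 percentage points lower from compound 1 to compound 2 (within the scatter). Among the compounds with values here, with only that step as a guide, no change beyond the scatter is expected in this assay. The expected step is a number 2.3 percentage points higher from compound 2 to compound 3 (within the scatter). The estimate for compound 3 is 4%, with an expected range from 0% to 12%.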

Compound 3, percent growth inhibition at one concentration: 9.2%
For compound 3 the middle estimate is 5.2 percentage points below the measured one, and the stated range covers the measured number.
By their numbers in this assay, from the lowest: compounds 2, 1 and 3 (each within the scatter of the next).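

With 4-chlorophenyl on the amide-type nitrogen, all three chlorophenyl forms can now be compared in this assay. The new compound gives a number 7.5 percentage points higher from compound 2 to compound 3 (within the scatter) and a number 3.5 percentage points higher from compound 1 to compound 3 (within the scatter). Moving the chlorine around the phenyl ring therefore separates none of the three compounds in this assay, and no available evidence bears on the result.

Going by these compounds, it remains open whether an amine or a carboxylic acid in place of the chlorine, or a longer chain in the shared core, would give a step beyond the scatter.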